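A few compounds are considered here, and "the series" means these few. Any claim that something is new, unique, unknown or untested is made for them only; others in the source may bear on it.

Working notes on the series, tested in a functional assay on SK-N-SH cells (Homo sapiens) for cytotoxicity, read by MTT assay, with a stated time of 24 h; on this read-out lower numbers stand for stronger inhibition and higher numbers for weaker inhibition. Compound 3 `O=c1nc2ccccn2cc1Cc1ccc(F)cc1` gives 125000 nM in this assay. Compound 2 `O=c1nc2ccc(Cl)cn2cc1Cc1ccc(F)cc1` gives 9860 nM in this assay. Within the data shown here, the single change between them, (chloro in place of hydrogen on an aromatic carbon), produces a 13-fold lower number from compound 3 to compound 2 (1.10 log units; beyond the scatter). Compound 1 `CC1(C)OC2O[C@@H](Cc3cn4ccccc4nc3=O)C(OCc3ccccc3)C2O1` carries a different core; the difference between the two cores is not broken down here. In this assay compound 1 returns only a limit, > 1000000 nM, and not a number. Among the measured compounds shown here, compound 1 is the one value sitting at the limit of > 1000000 nM in this assay, at which 1 of the 3 values shown sits.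

Compound 4 `CC1(C)OC2O[C@@H](Cc3cn4cc(Cl)ccc4nc3=O)C(OCc3ccccc3)C2O1` is not yet measured. It differs from compound 1 by chloro in place of hydrogen on an aromatic carbon, the same change as that from compound 3 to compound 2, at the same place. For compound 4 the expectation is an at least 3.3-fold lower number from compound 1 to compound 4 (0.52 log units; beyond the scatter). That expectation rests on the earlier 13-fold lower number from compound 3 to compound 2 (1.10 log units; beyond the scatter) and on the limit of compound 1, which leaves open how far there is to move, so a result that is again only a limit stays likely. Compound 4 is expected near 300000 nM, within 50000 nM to 1000000 nM.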

Compound 4, half-maximal inhibitory concentration: > 1000000 nM
Compound 4: no number, only a limit; the forecaster's own chance of this, stated with the estimate: 55%; middle value at least 3.3-fold (0.52 log units) from the limit.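

In this assay compound 4 returns only a limit, as compound 1 does, so no step can be read between compound 1 and compound 4: the limit of > 1000000 nM in this assay, at which 2 of the 4 values shown sit. The compounds shown leave open whether chloro in place of hydrogen on an aromatic carbon changes the number at all on the core of compound 1.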